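Working notes on a labdane-type series: butenolide to aldehyde

The source may report more compounds than this note shows. Statements on the series, on what has been measured and on what is new or still open speak of the compounds shown alone.

Measured compounds:
compound 1 `C=C1CC[C@H]2C(C)(C)CCC[C@]2(C)[C@H]1C/C=C1\CC(O)OC1=O`: 82.4%
compound 2 `C=C1CC[C@H]2C(C)(C)CCC[C@]2(C)[C@H]1C/C=C(\CCO)C(=O)O`: 88.3%
compound 3 `C=C1CC[C@H]2C(C)(C)CCC[C@]2(C)[C@H]1C/C=C1\C=COC1=O`: 99.6%

All three were run in a functional assay on RAW264.7 cells (Mus musculus) for inhibition, read by ELISA, with stated times of 1 h and 18 h, tested at 1 uM; on this read-out lower numbers stand for a stronger effect and higher numbers for a weaker effect at the one concentration tested. Among the three numbers compound 3 stands highest, that is, it shows the weakest effect at the single concentration tested. Its nearest neighbour is compound 2, whose number is lower by a margin beyond the scatter; compound 1 lies furthest away, lower still and also beyond the scatter. No two of these compounds differ in just one place, so no single step among them can be named; the numbers are only what they are.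

The next compound, compound 4 `C=C1CC[C@H]2C(C)(C)CCC[C@]2(C)[C@H]1CC=O`, has not been measured. Compared with compound 3 it differs as follows: a group of 2 heavy atoms (1 carbon, 1 oxygen; no ring) in place of a group of 7 heavy atoms (5 carbon, 2 oxygen; one five-membered non-aromatic ring with 1 hetero atom), on a saturated chain carbon bound to a saturated ring carbon

The effect of removing the five-membered ring with its two double bonds and keeping only a formyl group cannot be read off any measured pair. The three measured numbers cluster in the upper part of the scale, and compound 3, the closest structural relative, is the highest of them. Compound 4 is therefore expected to stay high as well, with a step from compound 3 of a number 6.6 percentage points lower from compound 3 to compound 4 (within the scatter), most likely within the scatter or a little downward. For compound 4 in this assay the estimate is 93%, with a range from 72% to 106%.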

Compound 4, a percentage reported as activity, at one concentration (the size of the read-out at that concentration, not a potency): 95%
Compound 4: middle estimate off by 2 percentage points, on the low side; the measured number falls inside the stated range.
By their numbers in this assay, from the lowest: compounds 1, 2, 4 and 3 (each within the scatter of the next, the first and the last beyond it).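

Among the compounds shown here, the step in this assay is a number 4.6 percentage points lower from compound 3 to compound 4 (within the scatter) and is the first that can be read at this place, a saturated chain carbon bound to a saturated ring carbon. Formyl in place of the five-membered non-aromatic ring thus leaves the read-out within the scatter at the one concentration tested, so the ring carried by compound 3 is not shown to matter for this read-out. Nothing at hand bears on the reason for this result.

Still open, on these data alone, is whether any group at this place moves the read-out beyond the scatter, for example an amine or a longer chain ending in a methyl ester. A single concentration also leaves open how compound 3 and compound 4 compare at higher concentrations.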